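The compounds below may be only part of what the source reports. "The series", "measured", "known", "first", "only" and "open" are said of these compounds alone.

Of the compounds shown here, three built on one shared core have been tested in a functional assay on U-937 cells (Homo sapiens) for cytotoxicity, read by MTT assay, with a stated time of 48 h; on this read-out higher numbers stand for weaker inhibition and lower numbers for stronger inhibition. Compound 1 `COc1ccccc1Nc1nc(-c2cccc(F)c2)nc2ccc(F)cc12` carries a 2-methoxyphenyl group on the ring nitrogen. In this assay compound 1 reaches only a limit of the assay, > 50000 nM. Compound 2 `Fc1cccc(Nc2nc(-c3cccc(F)c3)nc3ccc(F)cc23)c1` carries a 3-fluorophenyl group in that place, and in this assay compound 2 gives 42300 nM, a change of an at least 1.1-fold lower number from compound 1 to compound 2 (0.07 log units; that floor lies within the scatter). Compound 3 `Fc1cccc(-c2nc(Nc3cccc(Br)c3)c3cc(F)ccc3n2)c1` carries a 3-bromophenyl group. In this assay compound 3 again reaches only a limit of the assay, > 50000 nM. Swapping the halogen gives an at least 1.1-fold higher number from compound 2 to compound 3 (0.07 log units; that floor lies within the scatter), while the step that the two limits leave unreadable from compound 1 to compound 3 cannot be sized because both of its ends sit at the limit of > 50000 nM in this assay, at which 2 of the 3 values shown sit. So compound 3 stands at the weak end of what the numbers can show.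

Compound 4 `Oc1cccc(Nc2nc(-c3cccc(F)c3)nc3ccc(F)cc23)c1` has not yet been measured. It differs from compound 3 in one place: hydroxy in place of bromo on an aromatic carbon. Among the compounds with values here, the only readable step at that position, an at least 1.1-fold higher number from compound 2 to compound 3 (0.07 log units; that floor lies within the scatter), stayed within the scatter, and the ring swaps from compound 1 moved nothing beyond it. The expected step of a number no higher from compound 3 to compound 4 (the limit leaves the size open) is therefore none beyond the scatter. Compound 4 is estimated to give 50000 nM, between 20000 nM and 150000 nM, with a real chance that only a limit is reported.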

Compound 4, half-maximal inhibitory concentration: > 50000 nM
Compound 4 gave a limit, no number (the forecaster's own chance of this, stated with the estimate: 60%); the middle value lies on the limit itself.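

Putting hydroxy in place of bromo adds a hydrogen-bond donor and a hydrogen-bond acceptor, where bromo has neither, yet in this assay compound 4 still reaches only a limit and gives no number. Within the data shown here, the one step that can be read is an at least 1.1-fold higher number from compound 2 to compound 4 (0.07 log units; that floor lies within the scatter), so the data do not separate hydroxy from fluoro at this place, and compound 2 remains the only one of the halogen and hydroxy compounds with a measured number. The steps to compound 4 from compound 3 and from compound 1 cannot be read, because both ends of each are limits: the limit of > 50000 nM in this assay, at which 3 of the 4 values shown sit.

With so many values at that limit, the compounds shown cannot say how much a group at this place matters, or whether any group here could give clearly stronger inhibition. An amine, a carboxylic acid or a longer chain such as methoxyethyl at this place on the aniline ring would show whether the read-out can move well beyond the scatter in this series.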